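Thiol inhibitors: carboxy replaces chloro on the benzyl ring

The source may hold more compounds than are shown below. What is called first, only, known or untested is meant among the compounds shown, and "the series" means these compounds.

Measured so far:
compound 1 `O=C(NCC(=O)N1[C@@H](c2ccccc2O)CC[C@H]1C(=O)O)[C@@H](S)Cc1ccccc1` 1 nM
compound 2 `O=C(NCC(=O)N1[C@@H](c2ccccc2O)CC[C@H]1C(=O)O)[C@@H](S)Cc1ccc(O)cc1` 3.5 nM
compound 3 `O=C(NCC(=O)N1[C@@H](c2ccccc2O)CC[C@H]1C(=O)O)C(S)Cc1ccc(Cl)cc1` 1.2 nM

In an assay on isolated protein for inhibition of Neprilysin (Oryctolagus cuniculus) (a lower number here means a stronger inhibitor, a higher number a weaker inhibitor), compound 3 stands second highest of the three, indistinguishable from compound 1 a 1.2-fold higher number from compound 1 to compound 3 (0.08 log units; within the scatter) and clearly apart from compound 2 a 2.9-fold lower number from compound 2 to compound 3 (0.46 log units; beyond the scatter). Compound 4 `O=C(O)c1ccc(CC(S)C(=O)NCC(=O)N2[C@@H](c3ccccc3O)CC[C@H]2C(=O)O)cc1` differs from compound 3 by carboxy in place of chloro on an aromatic carbon, that is 4-chlorophenyl to 4-carboxyphenyl, para to a large group. Going by the values given here, the one earlier step that introduced a hydrogen-bond donor and acceptor at that aromatic carbon, a 3.5-fold higher number from compound 1 to compound 2 (0.54 log units; beyond the scatter), weakened binding modestly, while chloro left it unchanged a 1.2-fold higher number from compound 1 to compound 3 (0.08 log units; within the scatter). A comparable modest weakening is therefore expected for compound 4 in this assay, as a 3.3-fold higher number from compound 3 to compound 4 (0.52 log units; beyond the scatter). The expected value for compound 4 is 4 nM, within 1.5 nM to 12 nM.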

Compound 4, half-maximal inhibitory concentration: 62 nM
Beside the measured number, compound 4's estimate is 16-fold (1.19 log units) below it; the measured number lies above the stated range.
By their numbers in this assay, from the lowest: compounds 1 and 3 (each within the scatter of the next); then compound 2; then compound 4.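

On this aromatic carbon, the step of a 52-fold higher number from compound 3 to compound 4 (1.71 log units; beyond the scatter) in this assay is far larger than the step of a 3.5-fold higher number from compound 1 to compound 2 (0.54 log units; beyond the scatter) for hydroxy in place of hydrogen. The modest hydroxy step therefore did not predict the result for carboxy, although both groups carry a hydrogen-bond donor and acceptor. No measurement shown here explains the loss.

From the compounds shown here alone, whether a methyl ester, a primary amide or an amine at this carbon would give a similar loss remains open. So does the effect of a longer chain, such as carboxymethyl.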